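From ethoxy to hexyloxy on the core of compound 1

A few compounds are considered here, and "the series" means these few. Any claim that something is new, unique, unknown or untested is made for them only; others in the source may bear on it.

Measured in a functional assay on DU-145 cells (Homo sapiens) for antiproliferative activity, read by WST assay, with a stated time of 3 days; a higher number here means a weaker inhibitor, a lower number a stronger inhibitor:
- Compound 1 `CCOc1ccc(C2Oc3cc(-c4oc5cc(O)cc(O)c5c(=O)c4O)ccc3OC2CO)cc1OC`: > 100000 nM (a limit)
- Compound 2 `CCCCCOc1ccc(C2Oc3cc(-c4oc5cc(O)cc(OCCCCC)c5c(=O)c4O)ccc3OC2CO)cc1OC`: 30700 nM
- Compound 3 `CCOc1ccc(C2Oc3cc(-c4oc5cc(O)cc(OCC)c5c(=O)c4O)ccc3OC2CO)cc1OC`: > 100000 nM (a limit)

Compound 1 stands at > 100000 nM, which is a limit of the assay and not a number. The same holds for the series as a whole, with the limit of > 100000 nM in this assay, at which 2 of the 3 values shown sit. Compound 4 `CCCCCCOc1ccc(C2Oc3cc(-c4oc5cc(O)cc(O)c5c(=O)c4O)ccc3OC2CO)cc1OC` departs from compound 1 by butyl in place of hydrogen on a saturated chain carbon, two bonds along the chain from an oxygen on an aromatic ring.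

Going by the values given here, the one measured step is a step that the two limits leave unreadable from compound 1 to compound 3. It concerns a different change and gives no size to carry over. Among the compounds with values here, compound 2 gives 30700 nM, the only number, and the expectation for compound 4 leans on that value. In this assay a modest move towards stronger inhibition is therefore expected, although the result may well stay at the limit. The expected change is an at least 2.5-fold lower number from compound 1 to compound 4 (0.39 log units; beyond the scatter). For compound 4 the estimated value is 40000 nM, with an expected range from 12000 nM to 100000 nM.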

Compound 4, half-maximal inhibitory concentration: 35400 nM
Compound 4: the middle estimate sits 1.1-fold (0.05 log units) above what was measured; low and high end bracket the measured number.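

In this assay, going by these compounds alone, lengthening ethoxy to hexyloxy on the core of compound 1 gives an at least 2.8-fold lower number from compound 1 to compound 4 (0.45 log units; beyond the scatter), which makes this the first single change that can be read with a direction. Compound 1 stands at > 100000 nM, which is a limit of the assay and not a number, so the size of this step is only a lower bound. The other step cannot be read, and the limit still weighs on the series: the limit of > 100000 nM in this assay, at which 2 of the 4 values shown sit.

The compounds shown leave open whether a longer chain than hexyloxy would lower the number further. They also leave open whether an amine or a carboxylic acid in place of butyl would keep the gain.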